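From Chloro to Fluoro on a Shared Core

The compounds below may be only part of what the source reports. "The series", "measured", "known", "first", "only" and "open" are said of these compounds alone.

Among the measured compounds shown here, compound 2 `Clc1cc(Br)c2nnn(CC3CC3)c2c1` gives 60 nM in a functional assay on cells for positive allosteric modulation of metabotropic glutamate receptor 2 (Homo sapiens), read by fluorescence and calcium flux, with a stated time of 30 min (a higher number here means that more compound is needed for the effect, a lower number that less compound is needed), the lowest of the two numbers measured so far. Compound 1 `FC(F)(F)c1cc(Br)c2nnn(CC3CC3)c2c1` carries a trifluoromethyl group in place of the chloro group, and in this assay compound 1 gives 140 nM. For the measured compounds named here, the single measured step, a 2.3-fold lower number from compound 1 to compound 2 (0.37 log units; beyond the scatter), is the only guide available. Compound 3 `Fc1cc(Br)c2nnn(CC3CC3)c2c1` carries the change (fluoro in place of chloro on an aromatic carbon). Going by the values given here, this is a second swap at the same aromatic carbon, and the one known step there was modest in size. Among the compounds with values here, no measurement yet shows how a fluoro group behaves on this core, so a step of similar size in either direction, or none beyond the scatter, is all possible. For compound 3 an estimated value of 120 nM is expected, within a range from 50 nM to 300 nM. This estimate for compound 3 means an expected step of a 2.0-fold higher number from compound 2 to compound 3 (0.30 log units; within the scatter).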

Compound 3, half-maximal effective concentration: 70 nM
For compound 3 the middle estimate is 1.7-fold (0.23 log units) above the measured one; the measured number falls inside the stated range.
By their numbers in this assay, from the lowest: compounds 2, 3 and 1 (each within the scatter of the next, the first and the last beyond it).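

At this aromatic carbon, fluoro and chloro cannot be told apart in this assay, since the step of a 1.2-fold higher number from compound 2 to compound 3 (0.07 log units; within the scatter) lies within the scatter. The step of a 2.0-fold lower number from compound 1 to compound 3 (0.30 log units; within the scatter) also lies within the scatter, so fluoro cannot be separated from trifluoromethyl either, even though chloro and trifluoromethyl do differ beyond the scatter in the earlier step of a 2.3-fold lower number from compound 1 to compound 2 (0.37 log units; beyond the scatter) on the same core. Nothing available here gives a reason for these numbers.

The compounds shown leave open how this carbon would respond to a group of a different kind, such as an amine, a methoxy group or a nitrile. They also leave open whether these swaps would give steps of the same size if the bromo group on the shared core were replaced by another group.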